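The compounds below may be only part of what the source reports. "The series", "measured", "known", "first", "only" and "open" are said of these compounds alone.

Measured so far in a functional assay on A549 cells (Homo sapiens) for antiproliferative activity, read by CCK-8 assay, with a stated time of 72 h; a lower number here means a stronger inhibitor, a higher number a weaker inhibitor:
- compound 1 `COc1ccc(SCc2ccc(C(=O)Nc3ccccc3N)cc2)cc1`: 2570 nM
- compound 2 `CCc1ccc(SCc2ccc(C(=O)Nc3ccccc3N)cc2)cc1`: 3040 nM

Compound 1 and compound 2 are the only reference points, and they cannot be told apart: the measured difference is a 1.2-fold higher number from compound 1 to compound 2 (0.07 log units; within the scatter). Among the compounds with values here, compound 1 therefore stands level with the only other measured compound, and neither can be called the better one.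

Compound 3 `COc1ccc(SCc2ccc(C(=O)Nc3ccccc3N)cc2)cc1OC` differs from compound 1 by one change, methoxy in place of hydrogen on an aromatic carbon. The new group sits ortho to a methoxy group and meta to a large group.

Within the data shown here, only one measured step bears on this, ethyl in place of methoxy on an aromatic carbon, a 1.2-fold higher number from compound 1 to compound 2 (0.07 log units; within the scatter). Among the measured compounds shown here, it is a swap of one group for another, so it does not test the added group, and no measured compound carries a substituent at the new place. The evidence is thin, and it gives no direction for the change.

No shift beyond the scatter is expected in this assay, and the estimated step is a 1.1-fold higher number from compound 1 to compound 3 (0.04 log units; within the scatter). For compound 3 the expected value is 2800 nM, with an estimated range of 1300 nM to 6000 nM.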

Compound 3, half-maximal inhibitory concentration: 5680 nM
Beside the measured number, compound 3's estimate is 2.0-fold (0.31 log units) below it; low and high end bracket the measured number.
By their numbers in this assay, from the lowest: compounds 1, 2 and 3 (each within the scatter of the next, the first and the last beyond it).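

In this assay, the new methoxy, ortho to a methoxy group and meta to a large group, gives a 2.2-fold higher number from compound 1 to compound 3 (0.34 log units; beyond the scatter), a modest step but one beyond the scatter and towards weaker inhibition. Within the data shown here, this is the first measured sign that this ring position is sensitive to an added group, which the earlier swap at the existing ring substituent could not show, since that step, a 1.2-fold higher number from compound 1 to compound 2 (0.07 log units; within the scatter), stayed within the scatter and put nothing at the new place. A single addition is all that supports this reading, and no measurement on hand accounts for the shift.

The compounds shown leave open whether the loss belongs to methoxy itself or to any group at this place, a question that a fluorine atom, a hydroxy group or an amine there would help to settle. They also leave open whether the step depends on the neighbouring methoxy group, as a new methoxy on the ethyl-bearing compound 2 would show, and whether it holds outside this one antiproliferative read-out.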